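Closing the Amide Nitrogen into a Pyrrolidine Ring

The source may hold more compounds than are shown below. What is called first, only, known or untested is meant among the compounds shown, and "the series" means these compounds.

Compound 1, `COc1cc2c(cc1OC)C(CC(=O)NC(C)C)CC2`: 29.3%
Compound 2, `CCCCCCNC(=O)CC1CCc2cc(OC)c(OC)cc21`: 82.2%
Compound 3, `COc1cc2c(cc1OC)C(CC(=O)NCc1ccccc1)CC2`: 48.1%

Three amides built on one shared core were tested in a functional assay on the whole organism (strain Swiss albino) for inhibition, with Mus musculus as the target, in the writhing test, with stated times of 60 min and 15 min, at a dose of 100 mg/kg by the oral route; a lower number here means less inhibition, a higher number more inhibition at the dose given (going by the name of the read-out). Compound 1 gives the lowest of the three numbers; compound 3 stands nearest to it and compound 2 furthest, as the steps of a number 18.8 percentage points higher from compound 1 to compound 3 (beyond the scatter) and a number 52.9 percentage points higher from compound 1 to compound 2 (beyond the scatter) show. Compound 4, `COc1cc2c(cc1OC)C(CC(=O)N1CCCC1)CC2`, differs from compound 1 by pyrrolidin-1-yl in place of isopropylamino on a carbonyl carbon. For the measured compounds named here, no measured step makes this exact change, which removes the amide hydrogen; the two steps away from compound 1 both swap the isopropyl group on the amide nitrogen and both raise inhibition, the hexyl step by a large amount and the benzyl step modestly. A modest rise is therefore expected, a number 12.7 percentage points higher from compound 1 to compound 4 (beyond the scatter). Compound 4 is estimated at 42%, within 22% to 65%.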

Compound 4, a percentage reported as inhibition, in the whole organism at one dose (the size of the read-out at that dose, not a potency): 19.2%
The estimate for compound 4 lay 22.8 percentage points above the measured number; the whole stated range lies above it.
By their numbers in this assay, from the lowest: compound 4; then compound 1; then compound 3; then compound 2.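

Pyrrolidin-1-yl on the carbonyl carbon is the first change here to lower the number in this assay, with a number 10.1 percentage points lower from compound 1 to compound 4 (beyond the scatter), so replacing the isopropyl group does not always raise it. The gaps to the two other amides are wider, with a number 28.9 percentage points lower from compound 3 to compound 4 (beyond the scatter) and a number 63 percentage points lower from compound 2 to compound 4 (beyond the scatter). No measurement here gives a cause for these falls.

On these data alone, the loss of the amide hydrogen and the arrival of the ring come together in compound 4, so their separate contributions stay open. A dimethylamino group on the same carbonyl carbon, which has no amide hydrogen and no ring, would help separate them.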